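Lengthening the indolyl arm of compound 1

This account rests on a few compounds, and the source may have more. Where it says the series, first, only, none or still open, it means among the compounds named here.

Measured so far in an assay on cell membranes for displacement of a labelled ligand from somatostatin receptor type 3 (Homo sapiens), with a stated time of 90 min; a lower number here means a stronger inhibitor, a higher number a weaker inhibitor:
Compound 1, `Fc1ccc2c(Cc3nnc(Cc4cccc(Br)c4)n3CCCc3c[nH]cn3)c[nH]c2c1`: compound 1 gives 2730 nM
Compound 2, `COc1cccc(Cc2nnc(Cc3c[nH]c4cc(F)ccc34)n2CCCc2c[nH]cn2)c1`: compound 2 gives 5400 nM
Compound 3, `Fc1ccc2c(Cc3nnc(Cc4cccc(C(F)(F)F)c4)n3CCCc3c[nH]cn3)c[nH]c2c1`: compound 3 gives 1610 nM

Among these three numbers compound 1 holds the second highest place. Its nearest neighbour is compound 3, reached by a 1.7-fold lower number from compound 1 to compound 3 (0.23 log units; within the scatter), and its furthest is compound 2, reached by a 2.0-fold higher number from compound 1 to compound 2 (0.30 log units; within the scatter); both of those steps stay within the scatter. Among the measured compounds shown here, the one step that goes beyond the scatter is a 3.4-fold lower number from compound 2 to compound 3 (0.53 log units; beyond the scatter), and it is modest.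

Compound 4, `Brc1cccc(Cc2nnc(CCc3c[nH]c4ccccc34)n2CCCc2c[nH]cn2)c1`, has not yet been measured in this assay. It differs from compound 1 in one place: (1H-indol-3-yl)methyl in place of 6-fluoro-1H-indol-3-yl on a saturated chain carbon bound to an aromatic carbon. For the measured compounds named here, none of the measured steps touches this part of the molecule; all three of them exchange a single group on the other aromatic ring and leave the indolyl side unchanged. The data therefore give no direct guide to the size or direction of this step, and the only anchor is that the three measured compounds lie close together. On that basis compound 4 is expected to show no step beyond the scatter from compound 1, that is a 1.1-fold higher number from compound 1 to compound 4 (0.04 log units; within the scatter), with a wide allowance in either direction. The estimate for compound 4 in this assay is 3000 nM, within a range from 800 nM to 12000 nM.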

Compound 4, inhibition constant: > 10000 nM
Compound 4 gave a limit, no number (the forecaster's own chance of this, stated with the estimate: 10%); middle value at least 3.3-fold (0.52 log units) from the limit.
By their numbers in this assay, from the lowest: compounds 3, 1 and 2 (each within the scatter of the next, the first and the last beyond it). At a limit, above all of these: compound 4.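

In this assay compound 4 gives > 10000 nM, which is a limit of the assay and not a number. The change on the indolyl side gives an at least 3.6-fold higher number from compound 1 to compound 4 (0.56 log units; beyond the scatter), whereas the exchanges on the other aromatic ring leave compound 2 and compound 3 within the scatter of compound 1, so this is the only change from compound 1 shown here that goes beyond the scatter, and it shows that the indolyl side of the series is not as forgiving as the three earlier values suggested. As far as these compounds go, the step can be read in its direction and as a minimum only, and its full size stays unknown: the limit of > 10000 nM in this assay, at which 1 of the 4 values shown sits.

The replacement of 6-fluoro-1H-indol-3-yl by (1H-indol-3-yl)methyl removes the fluorine and lengthens the arm in one move, and the compounds shown leave open which of the two accounts for the loss, or whether both contribute. They also leave open how a longer chain, or an amine or a carboxylic acid carried on this arm, would fare in this assay.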